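This account rests on a few compounds, and the source may have more. Where it says the series, first, only, none or still open, it means among the compounds named here.

Going by the values given here, compound 2 (`Cc1ccc(NC(=O)Nc2cc(C)nc3ccccc23)cc1`) stands highest of the three compounds measured so far in an ADME assay for permeability, using PAMPA, at pH 7.4; a lower number here means that the compound crosses the layer more slowly, a higher number that the compound crosses the layer faster: compound 2 gives 669 10^-6 cm/s, while compound 3 (`Cc1cc(NC(=O)Nc2cccc(Cl)c2)c2ccccc2n1`) gives 566 10^-6 cm/s and compound 1 (`Cc1cc(NC(=O)Nc2ccc(C)c(Cl)c2)c2ccccc2n1`) gives 262 10^-6 cm/s. The gap from compound 2 to compound 3 is small, a 1.2-fold lower number from compound 2 to compound 3 (0.07 log units; within the scatter), whereas the steps from compound 1 are larger: a 2.6-fold higher number from compound 1 to compound 2 (0.41 log units; beyond the scatter) and a 2.2-fold higher number from compound 1 to compound 3 (0.33 log units; beyond the scatter).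

Compound 4 (`Cc1cc(NC(=O)Nc2ccc(C(F)(F)F)cc2)c2ccccc2n1`) differs from compound 2 in one place: trifluoromethyl in place of methyl on an aromatic carbon. Among the compounds with values here, no measured step exchanges a methyl for a trifluoromethyl, so none bears on this change directly. The nearest comparison is the step from compound 2 to compound 3, which exchanges one substituted phenyl on the amide-type nitrogen for another and stays within the scatter, a 1.2-fold lower number from compound 2 to compound 3 (0.07 log units; within the scatter). On that basis, the account expects no step beyond the scatter in this assay for compound 4, perhaps a slight fall: a 1.2-fold lower number from compound 2 to compound 4 (0.09 log units; within the scatter). The expected value for compound 4 is therefore 550 10^-6 cm/s, in a range from 300 10^-6 cm/s to 900 10^-6 cm/s.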

Compound 4, apparent permeability: 2 10^-6 cm/s
Beside the measured number, compound 4's estimate is 280-fold (2.44 log units) above it; the whole stated range lies above it.
By their numbers in this assay, from the lowest: compound 4; then compound 1; then compounds 3 and 2 (each within the scatter of the next).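

In this assay, going by these compounds alone, trifluoromethyl in place of methyl on this aromatic carbon, para to a large group, gives a 330-fold lower number from compound 2 to compound 4 (2.52 log units; beyond the scatter), so the number at this position can move far more than the earlier compounds suggested. The earlier changes to the substituted phenyl were much smaller, with a 2.6-fold higher number from compound 1 to compound 2 (0.41 log units; beyond the scatter) and a 1.2-fold lower number from compound 2 to compound 3 (0.07 log units; within the scatter). The compounds shown offer no measured basis for explaining so large a fall.

From the compounds shown here alone, it remains open whether the fall is particular to trifluoromethyl or would also follow from another group on this carbon, such as a nitrile, a methoxy group or a single fluorine. Going by these compounds, it is also open whether trifluoromethyl would give a step of this size if it stood elsewhere on the phenyl ring.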